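Lengthening an Aminoalkyl Chain on a Melatonin Ligand

A few compounds are considered here, and "the series" means these few. Any claim that something is new, unique, unknown or untested is made for them only; others in the source may bear on it.

Within the data shown here, compound 1 `CC(=O)NCCN(C)c1cccc(OCCCCN)c1` is the weaker of the two compounds measured so far. In an assay on cells for displacement of a labelled ligand from melatonin receptor type 1A (Homo sapiens), using the Cheng-Prusoff equation, with a stated time of 90 min (on this read-out higher numbers stand for weaker inhibition and lower numbers for stronger inhibition), compound 1 gives 3090 nM. Compound 2 `CC(=O)NCCN(C)c1cccc(OCCCCCCNC(=O)Oc2cccc(-c3cccc(C(N)=O)c3)c2)c1`, which carries a longer chain ending in a much larger group, gives 38.9 nM in this assay, a far lower number, beyond the usual scatter, though it differs from compound 1 in more than one place at once. Compound 3 `CC(=O)NCCN(C)c1cccc(OCCCCCCN)c1` has not been measured. It differs from compound 1 in one place: 2-aminoethyl in place of amino on a saturated chain carbon, four bonds along the chain from an oxygen on an aromatic ring. Among the measured compounds shown here, no single-change step between measured compounds exists to calibrate this change. The extended chain resembles that of compound 2, whose 38.9 nM is so much lower, but nothing separates the chain from the larger end group in that comparison. A small step toward a lower number is expected, a 2.1-fold lower number from compound 1 to compound 3 (0.31 log units; beyond the scatter), possibly not beyond the scatter. Compound 3 is expected to give 1500 nM in this assay, within 400 nM to 5000 nM.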

Compound 3, inhibition constant: 447 nM
Compound 3: the middle estimate sits 3.4-fold (0.53 log units) above what was measured; the range from low to high includes it.
By their numbers in this assay, from the lowest: compound 2; then compound 3; then compound 1.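

Lengthening the chain alone moves the number: with 2-aminoethyl in place of amino on a saturated chain carbon, four bonds along the chain from an oxygen on an aromatic ring, this assay shows a 6.9-fold lower number from compound 1 to compound 3 (0.84 log units; beyond the scatter) and so this position responds to a change that adds no ring. Compound 3 has the same chain as compound 2 without the large end group, and compound 3 gives 447 nM while compound 2 gives 38.9 nM in the same test, so the chain alone does not account for the whole gap to compound 2. No measurement here explains why the longer chain gives the lower number. 

As far as these compounds go, whether 3-aminopropyl or 4-aminobutyl at this place would lower the number further remains open. So does whether a small acetamide on the end amine would go the way of the large end group of compound 2.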